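A few compounds are considered here, and "the series" means these few. Any claim that something is new, unique, unknown or untested is made for them only; others in the source may bear on it.

In a functional assay on MCF7 cells (Homo sapiens) for inhibition, read by MTT assay, with a stated time of 72 h (on this read-out lower numbers stand for stronger inhibition and higher numbers for weaker inhibition), three compounds have been measured:
Compound 1 `Cc1cc(Nc2ccn(Cc3cccc4ccccc34)n2)n2nc(SCc3ccc(Br)cc3)nc2n1` gives 4310 nM.
Compound 2 `Cc1cc(Nc2cc(-c3ccc(Cl)cc3)[nH]n2)n2nc(SCc3ccc(Br)cc3)nc2n1` gives 3620 nM.
Compound 3 `Cc1ccc(Cn2ccc(Nc3cc(C)nc4nc(SCc5ccc(Br)cc5)nn34)n2)cc1` gives 11300 nM.

Compound 2 has the lowest number of the three; its gap to compound 1 lies within the scatter, so the two cannot be ranked, while compound 3 sits beyond the scatter above it. Compound 4 `Cc1cc(Nc2cc(-c3ccccc3)[nH]n2)n2nc(SCc3ccc(Br)cc3)nc2n1` differs from compound 2 by hydrogen in place of chloro on an aromatic carbon. Among the compounds with values here, the only measured single step, a 2.6-fold higher number from compound 1 to compound 3 (0.42 log units; beyond the scatter), concerns a different part of the molecule, so no measured step speaks directly to this change. Without such a guide, only a small step in this assay is expected from compound 2 to compound 4, a 1.4-fold higher number from compound 2 to compound 4 (0.16 log units; within the scatter), leaning toward a slightly higher number. Compound 4 is therefore estimated at 5200 nM, with a range from 2200 nM to 12500 nM.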

Compound 4, half-maximal inhibitory concentration: 2720 nM
Compound 4: the middle estimate sits 1.9-fold (0.28 log units) above what was measured, within the range that was stated.
By their numbers in this assay, from the lowest: compounds 4, 2 and 1 (each within the scatter of the next); then compound 3.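

Hydrogen in place of chloro on the aromatic carbon para to a large group gives a 1.3-fold lower number from compound 2 to compound 4 (0.12 log units; within the scatter) in this assay and is the first measured change at this position. At this level of precision, 4-chlorophenyl and phenyl cannot be told apart here, so the chloro is not needed to keep a number of this size. No supporting measurement offers an explanation for this result.

Going by these compounds, whether a methoxy, an amine or a carboxylic acid at this position would shift the number remains open.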